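A few compounds are considered here, and "the series" means these few. Any claim that something is new, unique, unknown or untested is made for them only; others in the source may bear on it.

Measured so far:
compound 1, `NC(=O)COc1cc(=O)oc2cc(OCc3cccc(Cl)c3)ccc12`, in an assay on isolated protein (strain Sprague-Dawley) for inhibition of Amine oxidase [flavin-containing] A (Rattus norvegicus), read by spectrophotometry, with a stated time of 5 min (on this read-out lower numbers stand for stronger inhibition and higher numbers for weaker inhibition), gives 24000 nM;
compound 2, `CNc1cc(=O)oc2cc(OCc3cccc(Cl)c3)ccc12`, in this assay gives 4070 nM.

For the measured compounds named here, compound 2 stands lowest of the two numbers; its only neighbour is compound 1, and the step of a 5.9-fold lower number from compound 1 to compound 2 (0.77 log units; beyond the scatter) lies beyond the scatter. Compound 3 is `CCNc1cc(=O)oc2cc(OCc3cccc(Cl)c3)ccc12`. It differs from compound 2 by methyl in place of hydrogen on a saturated chain carbon bound to a nitrogen on an aromatic ring, a single added carbon on the chain attached to the ring nitrogen.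

Going by the values given here, no measured step bears directly on this change: the one known step swaps a whole group on the aromatic carbon rather than lengthening a chain on a nitrogen. With nothing to anchor a direction, the expected change in this assay is small, likely within the scatter, and is estimated as a 1.2-fold lower number from compound 2 to compound 3 (0.07 log units; within the scatter). Compound 3 is therefore expected to give about 3500 nM, with a range from 1200 nM to 10000 nM.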

Compound 3, half-maximal inhibitory concentration: 9330 nM
Estimate against measurement, compound 3: 2.7-fold (0.43 log units) below; the measured number falls inside the stated range.
By their numbers in this assay, from the lowest: compound 2; then compound 3; then compound 1.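

In this assay, going from methylamino to ethylamino weakens inhibition (a 2.3-fold higher number from compound 2 to compound 3 (0.36 log units; beyond the scatter)), so this position is sensitive to even a single added carbon on the chain. Ethylamino in place of carbamoylmethoxy still gives stronger inhibition (a 2.6-fold lower number from compound 1 to compound 3 (0.41 log units; beyond the scatter)), so compound 3 keeps part of the gain seen with compound 2, though less of it. No evidence is available to explain why one added methyl has this effect.

From the compounds shown here alone, whether a longer chain such as propyl on the same nitrogen would weaken inhibition further remains open. So does whether the plain amine, with no carbon on the nitrogen, or a dimethylamino group would give a lower number than compound 2.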